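The source may hold more compounds than are shown below. What is called first, only, known or untested is meant among the compounds shown, and "the series" means these compounds.

Measured compounds:
- Compound 1 `Cn1c(NN)nc(-c2ccco2)c(C#N)c1=O`: 58 ug/mL
- Compound 2 `CCOC(=O)c1cnn(-c2nc(-c3ccc(Cl)cc3)c(C#N)c(=O)n2C)c1N`: 94 ug/mL
- Compound 3 `Cn1c(NN)nc(-c2ccc(Cl)cc2)c(C#N)c1=O`: 41 ug/mL

All three were tested in a functional assay, with a stated time of 10 min; on this read-out lower numbers stand for stronger inhibition and higher numbers for weaker inhibition. Compound 2 gives the highest of the three numbers, but its gap to compound 1 lies within the usual scatter of repeated measurements, so the two cannot be told apart. Compound 3 stands beyond the scatter below compound 2, so compound 3 is the one that inhibits more strongly of that pair.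

Compound 4 `CCOC(=O)c1cnn(-c2nc(-c3cccs3)c(C#N)c(=O)n2C)c1N` has not yet been measured. Compared with compound 2, its structure changes in one place: thiophen-2-yl in place of 4-chlorophenyl on an aromatic carbon

For the measured compounds named here, no measured pair differs in only one place, so no direct step is available to lean on. Among the measured compounds, compound 1 carries a five-membered ring and compound 3 a six-membered one, and their values sit within the scatter of each other, which suggests that swapping ring types need not move the number much. The step is therefore expected to be small, with no clear direction beyond the scatter: a 1.1-fold higher number from compound 2 to compound 4 (0.03 log units; within the scatter). Compound 4 is estimated at 100 ug/mL, with a range from 50 ug/mL to 200 ug/mL.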

Compound 4, half-maximal inhibitory concentration: 109 ug/mL
Compound 4: the middle estimate sits 1.1-fold (0.04 log units) below what was measured, and the stated range covers the measured number.
By their numbers in this assay, from the lowest: compounds 3, 1, 2 and 4 (each within the scatter of the next, the first and the last beyond it).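

This is the first one-place comparison among the compounds shown: in this assay, putting thiophen-2-yl in place of 4-chlorophenyl, on the aromatic carbon next to the ring nitrogen and ortho to a cyano group, gives a step that cannot be told apart from repeat-measurement noise (a 1.2-fold higher number from compound 2 to compound 4 (0.06 log units; within the scatter)). For this one pair, the read-out therefore does not separate a six-membered aromatic ring of carbon only, bearing chlorine, from a five-membered aromatic ring with one hetero atom at this position. Nothing available gives a reason for this result.

Still open, as far as these compounds go, is whether a different kind of group at this position, such as an amine or a carboxylic acid, would shift the number beyond the scatter. Also open, from the compounds shown here alone, is whether thiophen-2-yl and 4-chlorophenyl would match on another core, such as that of compound 3.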